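The source may hold more compounds than are shown below. What is called first, only, known or untested is meant among the compounds shown, and "the series" means these compounds.

Of the compounds shown here, two built on the same core have been measured in a functional assay (aorta) with Rattus norvegicus as the target; on this read-out higher numbers stand for weaker inhibition and lower numbers for stronger inhibition. Compound 1, `CC(C)c1cn2ccccc2c1S(=O)(=O)c1ccc(OCCCN2CCN(c3ccccc3)CC2)cc1`, gives 205 nM in this assay. Compound 2, `CCCN(CCC)CCCOc1ccc(S(=O)(=O)c2c(CC)cn3ccccc23)cc1`, which carries a different amine at the end of its chain, gives 150 nM in this assay. These two numbers lie within the usual scatter of each other, so compound 1 cannot be set apart from compound 2 on the numbers at hand, and neither can be called the stronger inhibitor.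

Compound 3, `CC(C)c1cn2ccccc2c1S(=O)(=O)c1ccc(OCCCNC(C)(C)C)cc1`, has not yet been measured. It differs from compound 1 in a single place: (tert-butyl)amino in place of 4-phenylpiperazin-1-yl on a saturated chain carbon, three bonds along the chain from an oxygen on an aromatic ring. Going by the values given here, no step between two measured compounds carries this particular change, so the expectation rests only on the observation that compound 1 and compound 2, whose amines differ, give numbers that agree. Compound 3 is therefore expected to show a step of a 1.2-fold higher number from compound 1 to compound 3 (0.09 log units; within the scatter) in this assay that stays near the scatter, with no clear direction. For compound 3 the estimated value in this assay is 250 nM, with a range from 80 nM to 800 nM.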

Compound 3, half-maximal inhibitory concentration: 41.8 nM
Estimate against measurement, compound 3: 6.0-fold (0.78 log units) above; the measured number lies below the stated range.
By their numbers in this assay, from the lowest: compound 3; then compounds 2 and 1 (each within the scatter of the next).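

In this assay, replacing 4-phenylpiperazin-1-yl with (tert-butyl)amino on a saturated chain carbon, three bonds along the chain from an oxygen on an aromatic ring, gives a 4.9-fold lower number from compound 1 to compound 3 (0.69 log units; beyond the scatter), which corresponds to stronger inhibition. Going by these compounds alone, this is the first change made in this one place alone, and it shows that the group at the end of the chain can shift the read-out beyond the usual scatter, which the earlier pair could not show. Nothing available bears on why this happens.

The change alters several things at once: the entering group is smaller, has no ring, and brings a hydrogen-bond donor that the leaving group lacks, so this single step cannot separate these differences. Going by these compounds, a piperazin-1-yl group without the phenyl ring, or a cyclohexylamino group with a ring but still the hydrogen on nitrogen, would help to show which of them goes with the lower number, and it also remains open whether the step would carry over to a core with a different alkyl group.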